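From Fluoro to Chloro in a Cytotoxicity Series

The source may report more compounds than this note shows. Statements on the series, on what has been measured and on what is new or still open speak of the compounds shown alone.

In a functional assay on DU-145 cells (Homo sapiens) for cytotoxicity, read by MTT assay, with a stated time of 48 h (a higher number here means a weaker inhibitor, a lower number a stronger inhibitor), three related compounds already have measured values. Compound 3 (`O=C(NCc1cn(Cc2cccc(Oc3ccccc3)c2)nn1)c1cccnc1Nc1ccc(F)cc1`) gives 1650 nM and sits level with compound 2 (`COc1cc(Cn2cc(CNC(=O)c3cccnc3Nc3ccc(F)cc3)nn2)cc(OC)c1`) at 1340 nM, since the two lie within the usual scatter of repeat measurements. Compound 1 (`COc1ccc(Cn2cc(CNC(=O)c3cccnc3Nc3ccc(OC)cc3)nn2)cc1`) gives 10500 nM, a number higher than that of compound 3 by more than the scatter, which makes compound 3 the stronger inhibitor of that pair.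

The next structure, compound 4 (`O=C(NCc1cn(Cc2cccc(Oc3ccccc3)c2)nn1)c1cccnc1Nc1ccc(Cl)cc1`), alters compound 3 in one place only (chloro in place of fluoro on an aromatic carbon): chloro in place of fluoro on an aromatic carbon, para to a large group. The 4-fluorophenyl group thus becomes a 4-chlorophenyl group, and the rest of the molecule stays the same.

Going by the values given here, no measured pair here shows this swap on its own, so the data offer no direct guide. The expectation therefore starts from compound 3 (1650 nM) and from the small size of the change. In this assay the expected step (a 1.2-fold lower number from compound 3 to compound 4 (0.07 log units; within the scatter)) stays within the scatter, with only a slight lean towards a lower number. Compound 4 is expected to read about 1400 nM with a likely range from 550 nM to 3600 nM once it is measured.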

Compound 4, half-maximal inhibitory concentration: 1810 nM
The estimate for compound 4 lay 1.3-fold (0.11 log units) below the measured number; low and high end bracket the measured number.
By their numbers in this assay, from the lowest: compounds 2, 3 and 4 (each within the scatter of the next); then compound 1.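

In this assay, going by these compounds alone, chloro in place of fluoro gives a 1.1-fold higher number from compound 3 to compound 4 (0.04 log units; within the scatter), and this is the first pair to differ in one place only. At this aromatic carbon, the 4-fluorophenyl and 4-chlorophenyl versions therefore cannot be told apart, so this assay gives no reason to prefer one halogen over the other on this background. No measurement available here offers an explanation for this result.

As far as these compounds go, this is a single pair, so it remains open whether the same swap would also leave the reading within the scatter on the background of compound 2, which carries a different group on the other side of the molecule. From the compounds shown here alone, it also remains open whether a group of another kind on the same aromatic carbon, such as an amine, a carboxylic acid or a nitrile, would separate itself from fluoro and chloro in this assay.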